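Sulfonyl to benzylsulfanyl swap on the enone chain

This account rests on a few compounds, and the source may have more. Where it says the series, first, only, none or still open, it means among the compounds named here.

Measured so far:
compound 1 `Cc1ccc(CS/C(=C/c2c[nH]c3ccc(Br)cc23)C(=O)c2ccc(Cl)cc2)cc1`, 1000 nM
compound 2 `Cc1ccc(S(=O)(=O)/C(=C/c2ccc(N(C)C)cc2)C(=O)c2ccc(Cl)cc2)cc1`, > 100000 nM

In a functional assay on DU-145 cells (Homo sapiens) for inhibition, read by trypan blue exclusion, with a stated time of 96 h (on this read-out higher numbers stand for weaker inhibition of growth and lower numbers for stronger inhibition of growth), compound 1 gives 1000 nM. For compound 2 the assay reports only a limit, > 100000 nM. That reading is the limit of > 100000 nM in this assay, at which 1 of the 2 values shown sits, so compound 2 stands at the weak end of the two numbers shown, and no step between it and compound 1 is computed, the two differing in more than one place.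

Compound 3 `Cc1ccc(CS/C(=C/c2ccc(N(C)C)cc2)C(=O)c2ccc(Cl)cc2)cc1` keeps the rest of compound 2 and differs in one place: (4-methylbenzyl)sulfanyl in place of (4-methylphenyl)sulfonyl on a double-bonded chain carbon bound to a carbonyl carbon and a double-bonded chain carbon. Compound 1 carries the same (4-methylbenzyl)sulfanyl group on a different aryl partner and sits at a number rather than a limit. Among the measured compounds shown here, with no measured step to lean on, the size of the change is read only from where compound 2 sits. In this assay a step toward stronger inhibition is expected, of a size beyond the scatter, though the limit for compound 2 leaves the true starting point open. Compound 3 is expected to give 5000 nM, within 800 nM to 50000 nM. This estimate is expected to mean a step of an at least 20-fold lower number from compound 2 to compound 3 (1.30 log units; beyond the scatter).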

Compound 3, concentration for 50% growth inhibition: > 100000 nM
Compound 3 was reported as a limit; the forecaster's own chance of this, stated with the estimate: 20%; at least 20-fold (1.30 log units) between middle value and limit.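

In this assay compound 3 gives > 100000 nM, which is a limit and not a number. The change from (4-methylphenyl)sulfonyl to (4-methylbenzyl)sulfanyl therefore has no readable size at this position, and this series shows no gain from it with 4-(dimethylamino)phenyl in the molecule, because both members of the pair rest at the same end of the read-out: the limit of > 100000 nM in this assay, at which 2 of the 3 values shown sit.

The new information comes from the other pair: with (4-methylbenzyl)sulfanyl held fixed, 4-(dimethylamino)phenyl in place of 5-bromo-1H-indol-3-yl on a double-bonded chain carbon bound to a double-bonded chain carbon gives an at least 100-fold higher number from compound 1 to compound 3 (2.00 log units; beyond the scatter), so for this pair the aryl partner accounts for a large difference.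

Open, from the compounds shown here alone, is how (4-methylphenyl)sulfonyl compares with (4-methylbenzyl)sulfanyl when 5-bromo-1H-indol-3-yl is the aryl partner, since the sulfonyl group appears here only with 4-(dimethylamino)phenyl. Also open, going by these compounds, is whether the difference follows the bromine or the rest of the aryl partner, a question that a 1H-indol-3-yl without bromine or a plain phenyl at that place would address.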